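The source may report more compounds than this note shows. Statements on the series, on what has been measured and on what is new or still open speak of the compounds shown alone.

Working notes on a small series examined in a functional assay on MCF7 cells (Homo sapiens) for inhibition, read by sulforhodamine B assay, with a stated time of 24 h; on this read-out lower numbers stand for stronger inhibition of growth and higher numbers for weaker inhibition of growth. Compound 1 `CC1=C(C(=O)Nc2ccc(C)cc2)C(c2cn(-c3ccccc3)nc2-c2ccccc2)NC(=S)N1` gives 56100 nM in this assay. Compound 2 `COc1ccc(NC(=O)C2=C(C)NC(=S)NC2c2cn(-c3ccccc3)nc2-c2ccccc2)cc1` differs from compound 1 by methoxy in place of methyl on an aromatic carbon; in this assay compound 2 gives 77300 nM, and the step is a 1.4-fold higher number from compound 1 to compound 2 (0.14 log units; within the scatter). Compound 3 `CC1=C(C(=O)Nc2ccc(C)cc2)C(c2cn(-c3ccccc3)nc2-c2ccc(Cl)cc2)NC(=S)N1` in this assay gives 43500 nM, and the step is a 1.3-fold lower number from compound 1 to compound 3 (0.11 log units; within the scatter). All three numbers lie within the scatter of one another, so no order is read from them.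

Compound 4 `COc1ccc(NC(=O)C2=C(C)NC(=S)NC2c2cn(-c3ccccc3)nc2-c2ccc(Cl)cc2)cc1` has not yet been measured in this assay. It differs from compound 3 by methoxy in place of methyl on an aromatic carbon. The same change is also made from compound 1 to compound 2, where it gave a 1.4-fold higher number from compound 1 to compound 2 (0.14 log units; within the scatter); among the compounds here it occurs on two pairs in all. The cores on which the change is made differ by chloro in place of hydrogen on an aromatic carbon. The two place lines read the same word for word, so this is the same kind of change carried onto a different core.

Expectation: because the earlier step was a 1.4-fold higher number from compound 1 to compound 2 (0.14 log units; within the scatter) and compound 3 gives 43500 nM, the step expected here is a 1.4-fold higher number from compound 3 to compound 4 (0.14 log units; within the scatter), which would sit within the scatter. Compound 4 is accordingly estimated to give 60000 nM in this assay. The expected range for compound 4 runs from 30000 nM to 120000 nM.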

Compound 4, concentration for 50% growth inhibition: 70000 nM
Compound 4: middle estimate off by 1.2-fold (0.07 log units), on the low side; the range from low to high includes it.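

Carried onto the core of compound 3, methoxy in place of methyl gives a 1.6-fold higher number from compound 3 to compound 4 (0.21 log units; within the scatter), and in this assay this step does not differ from the one on the core of compound 1: the same change on two cores in this assay, a 1.4-fold higher number (0.14 log units; within the scatter) from compound 1 to compound 2 and a 1.6-fold higher number (0.21 log units; within the scatter) from compound 3 to compound 4, 1.2-fold (0.07 log units) apart, within the scatter of two such steps

The chloro change, read on the methoxy-bearing pair, gives a 1.1-fold lower number from compound 2 to compound 4 (0.04 log units; within the scatter), and it likewise agrees with its earlier counterpart: the same change on two cores in this assay, a 1.3-fold lower number (0.11 log units; within the scatter) from compound 1 to compound 3 and a 1.1-fold lower number (0.04 log units; within the scatter) from compound 2 to compound 4, 1.2-fold (0.07 log units) apart, within the scatter of two such steps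

Within these four compounds, each change reads the same on both cores, but every step lies within the scatter, so the agreement is only between steps that cannot be told from no step at all, and it does not show that either change alters growth inhibition or that a change of measurable size would carry across in the same way.

As far as these compounds go, what remains open is whether a different group in the place of the methyl and the methoxy, such as an amine, a hydroxyl or a carboxylic acid, would give a step beyond the scatter. From the compounds shown here alone, it is also open whether any such step would hold on both cores, or on a core bearing something other than hydrogen or chloro at that aromatic carbon, such as a nitrile or a trifluoromethyl.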